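From a Benzoate Ester to a Benzyl Carbamate

A few compounds are considered here, and "the series" means these few. Any claim that something is new, unique, unknown or untested is made for them only; others in the source may bear on it.

Three compounds have been measured in an assay on NIH3T3 cells with Urotensin-2 receptor (Homo sapiens) as the target; on this read-out higher numbers stand for an effect only at larger amounts of compound and lower numbers for an effect already at smaller amounts:
Compound 1 `CCc1ccccc1C(=O)OC(CCN(C)C)c1ccc(Cl)cc1` gives 1290 nM.
Compound 2 `Cc1cc(C)c(C(=O)OC(CCN(C)C)c2ccc(Cl)cc2)cc1C` gives 468 nM.
Compound 3 `COc1cccc(C(=O)NC(CCN(C)C)c2ccc(Cl)cc2)c1C` gives 4270 nM.

Compound 1 thus stands second highest of the three numbers. Compound 2 gives a lower number, and that gap lies beyond the usual scatter of repeated measurements; compound 3 gives a higher number, also beyond the scatter.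

Compound 4 `CN(C)CCC(OC(=O)NCc1ccccc1)c1ccc(Cl)cc1` has not yet been measured. It differs from compound 1 in one place: benzylamino in place of 2-ethylphenyl on a carbonyl carbon. The carbonyl carbon and the oxygen next to it remain, so the ester of compound 1 becomes a carbamate in compound 4.

Among the compounds with values here, no measured pair shows this exact change, so the expectation rests on the spread of the three numbers. Within the data shown here, the only measured compound with a different link at the carbonyl is compound 3, and compound 3 gives 4270 nM. A moderate upward step, beyond the scatter, is expected: a 1.9-fold higher number from compound 1 to compound 4 (0.29 log units; within the scatter). Compound 4 is therefore expected to give about 2500 nM, within a range from 700 nM to 9000 nM.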

Compound 4, half-maximal effective concentration: 2140 nM
Compound 4: middle estimate off by 1.2-fold (0.07 log units), on the high side; measured number inside the range.
By their numbers in this assay, from the lowest: compound 2; then compounds 1, 4 and 3 (each within the scatter of the next, the first and the last beyond it).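

In this assay, within the data shown here, benzylamino in place of 2-ethylphenyl on a carbonyl carbon gives a 1.7-fold higher number from compound 1 to compound 4 (0.22 log units; within the scatter), the first step that changes only one place. On this read-out, the ester of compound 1 and the carbamate of compound 4 therefore cannot be told apart, even though the entering group brings a nitrogen and 1 hydrogen-bond donor while the leaving group has neither. The data offer no explanation for how close these two numbers are.

The compounds shown leave open how much the group on this carbonyl carbon can vary while the number stays in this range. A phenylamino group, with no carbon before the ring, or a 2-phenylethylamino group, with a longer chain, could tell whether the length of that link matters.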